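Swapping a thiophene for a chlorophenyl on the shared core

The compounds below may be only part of what the source reports. "The series", "measured", "known", "first", "only" and "open" are said of these compounds alone.

Measured compounds:
- compound 1 `c1ccc(-c2ccnc3c2c(-c2ccccc2)nn3-c2ccccc2)cc1`: 3210 nM
- compound 2 `Brc1ccc(-c2ccnc3c2c(-c2ccccc2)nn3-c2ccccc2)cc1`: 49900 nM
- compound 3 `c1ccc(-c2nn(-c3ccccc3)c3nccc(-c4cccs4)c23)cc1`: 39300 nM

In a functional assay on HepG2 cells (Homo sapiens) for inhibition, read by MTT assay, with a stated time of 48 h (on this read-out higher numbers stand for weaker inhibition and lower numbers for stronger inhibition), compound 1 gives 3210 nM. Against this, compound 3 stands second highest of the three numbers: its nearest neighbour is compound 2, whose value is within the scatter of it (a 1.3-fold lower number from compound 2 to compound 3 (0.10 log units; within the scatter)), and its furthest is compound 1 (a 12-fold higher number from compound 1 to compound 3 (1.09 log units; beyond the scatter)).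

Compound 4 `Clc1ccc(-c2ccnc3c2c(-c2ccccc2)nn3-c2ccccc2)cc1` differs from compound 3 in one place: 4-chlorophenyl in place of thiophen-2-yl on an aromatic carbon. Among the compounds with values here, two measured steps bear on this. Putting bromo on the phenyl of compound 1 gave a large weakening (a 16-fold higher number from compound 1 to compound 2 (1.19 log units; beyond the scatter)), and putting thiophen-2-yl in place of that phenyl gave a large weakening of about the same size (a 12-fold higher number from compound 1 to compound 3 (1.09 log units; beyond the scatter)). A 4-chlorophenyl group resembles the 4-bromophenyl of compound 2 more than the thiophen-2-yl of compound 3, so compound 4 is expected to land near compound 2, and the step from compound 3 is expected to stay within the scatter (a 1.3-fold lower number from compound 3 to compound 4 (0.12 log units; within the scatter)).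

For compound 4 in this assay the estimate is 30000 nM, with a range from 10000 nM to 90000 nM.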

Compound 4, half-maximal inhibitory concentration: 61100 nM
Estimate against measurement, compound 4: 2.0-fold (0.31 log units) below; low and high end bracket the measured number.
By their numbers in this assay, from the lowest: compound 1; then compounds 3, 2 and 4 (each within the scatter of the next).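

In this assay, a chloro group on the phenyl costs about as much as bromo did, a large weakening (a 19-fold higher number from compound 1 to compound 4 (1.28 log units; beyond the scatter)), so the loss seen with compound 2 is not confined to bromo. Chloro and bromo cannot be told apart here (a 1.2-fold higher number from compound 2 to compound 4 (0.09 log units; within the scatter)), and neither can 4-chlorophenyl and thiophen-2-yl (a 1.6-fold higher number from compound 3 to compound 4 (0.19 log units; within the scatter)), so at this aromatic carbon, opposite the ring nitrogen, the three replacements for the plain phenyl of compound 1 form one group, well apart from compound 1 itself. Nothing measured here explains why compound 1 stands apart from the other three.

Still open, going by these compounds, is whether any group on this phenyl brings the same loss, or whether a methoxy group, an amine or a carboxylic acid in place of the halogen would return the number towards that of compound 1. On these data alone, the other two phenyl groups on the shared core are the same in all four compounds, so their contribution to the activity in this assay remains unknown.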